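Methoxy removal on two cores in a growth-inhibition series

The source may hold more compounds than are shown below. What is called first, only, known or untested is meant among the compounds shown, and "the series" means these compounds.

Compound 1 `COc1ccc2[nH]c(-c3ccccc3)c(C=C(C#N)C#N)c2c1`, compound 2 `COc1ccc(-c2[nH]c3ccc(OC)cc3c2C=C(C#N)C#N)cc1` and compound 3 `COc1ccc2[nH]c(-c3ccccc3)c(/C=C(\C#N)S(=O)(=O)c3ccccc3)c2c1` have been run in a functional assay on NCI-H23 cells (Homo sapiens) for inhibition, read by sulforhodamine B assay, with a stated time of 48 h; on this read-out higher numbers stand for weaker inhibition of growth and lower numbers for stronger inhibition of growth. In this assay compound 2 gives 2000 nM, compound 1 gives 4100 nM and compound 3 gives 8000 nM. The change hydrogen in place of methoxy on an aromatic carbon made a 2.1-fold higher number from compound 2 to compound 1 (0.31 log units; beyond the scatter). How the cores of compound 2 and compound 3 differ is not broken down here. Compound 4 `N#C/C(=C\c1c(-c2ccccc2)[nH]c2ccccc12)S(=O)(=O)c1ccccc1` awaits measurement in this assay; it arises from compound 3 by hydrogen in place of methoxy on an aromatic carbon, the same kind of change, but placed on a ring that is part of a fused or bridged system of two rings, meta and para to a fused ring, rather than para to a large group. Among the compounds with values here, the expectation rests on the one earlier instance, a 2.1-fold higher number from compound 2 to compound 1 (0.31 log units; beyond the scatter). Compound 4 is expected to give about 13000 nM, with a range from 5000 nM to 40000 nM, meaning an expected 1.6-fold higher number from compound 3 to compound 4 (0.21 log units; within the scatter).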

Compound 4, concentration for 50% growth inhibition: 4700 nM
Compound 4: the middle estimate sits 2.8-fold (0.44 log units) above what was measured; the measured number lies below the stated range.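

In this assay, within the data shown here, replacing the methoxy on the core of compound 3 with hydrogen gives a 1.7-fold lower number from compound 3 to compound 4 (0.23 log units; within the scatter), so on this core the change produces no step clear of the usual scatter. The change does not carry over as a constant step between the two cores: the same change on two cores in this assay, a 2.1-fold higher number (0.31 log units; beyond the scatter) from compound 2 to compound 1 and a 1.7-fold lower number (0.23 log units; within the scatter) from compound 3 to compound 4, 3.5-fold (0.54 log units) apart, beyond the scatter of two such steps. Among these compounds, with one pair per core, this shows only that the step on one core did not predict the step on the other, not why the two differ or how the change would behave on a further core.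

The two pairs differ both in where the methoxy sits and in the rest of the core, so the compounds shown leave open which of these separates the steps. Also open, as far as these compounds go, is how an amine or a carboxylic acid in place of the methoxy would read in this assay.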